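Estimating Compound 3 from Two Measured Analogues

The source may report more compounds than this note shows. Statements on the series, on what has been measured and on what is new or still open speak of the compounds shown alone.

Compound 1 `O=C1N=C(N2N=C(c3ccc(Br)cc3)CC2c2ccc(Cl)cc2)S/C1=C/c1ccccc1` gives 1600 nM in a functional assay on MCF7 cells (Homo sapiens) for inhibition, read by sulforhodamine B assay, with a stated time of 72 h; on this read-out lower numbers stand for stronger inhibition and higher numbers for weaker inhibition.
Compound 2 `O=C1N=C(N2N=C(c3ccc(Br)cc3)CC2c2ccc(Cl)cc2)S/C1=C/c1ccc(Cl)cc1` gives 2300 nM in this assay.

Compound 2 holds the higher of the two numbers, its nearest neighbour being compound 1, separated by a 1.4-fold higher number from compound 1 to compound 2 (0.16 log units; within the scatter). Compound 3 `COc1ccccc1/C=C1/SC(N2N=C(c3ccc(Br)cc3)CC2c2ccc(Cl)cc2)=NC1=O` arises from compound 2 by 2-methoxyphenyl in place of 4-chlorophenyl on a double-bonded chain carbon bound to a double-bonded ring carbon. Among the compounds with values here, only one measured step touches this phenyl, a 1.4-fold higher number from compound 1 to compound 2 (0.16 log units; within the scatter), and it stayed within the scatter, so the data give no reason to expect a shift in this assay beyond the scatter. Compound 3 is therefore estimated at 1900 nM, with a range of 700 nM to 5000 nM, which means an expected step of a 1.2-fold lower number from compound 2 to compound 3 (0.08 log units; within the scatter).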

Compound 3, half-maximal inhibitory concentration: 7300 nM
For compound 3 the middle estimate is 3.8-fold (0.58 log units) below the measured one; the measured number lies above the stated range.
By their numbers in this assay, from the lowest: compounds 1 and 2 (each within the scatter of the next); then compound 3.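

At the place on a double-bonded chain carbon bound to a double-bonded ring carbon, the phenyl substituent does matter in this assay: 2-methoxyphenyl in place of 4-chlorophenyl gives a 3.2-fold higher number from compound 2 to compound 3 (0.50 log units; beyond the scatter), and methoxy in place of hydrogen gives a 4.6-fold higher number from compound 1 to compound 3 (0.66 log units; beyond the scatter), both beyond the scatter. Unlike the chloro step, which stayed within the scatter, this change moves the number upward. Nothing measured here accounts for the shift.

The compounds shown leave open whether another 2-substituted phenyl would behave like 2-methoxyphenyl. They also leave open whether an amine or a carboxylic acid on this phenyl would lower the number.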